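The source may report more compounds than this note shows. Statements on the series, on what has been measured and on what is new or still open speak of the compounds shown alone.

In a functional assay on MCF7 cells (Homo sapiens) for antiproliferative activity, read by sulforhodamine B assay, with a stated time of 72 h (on this read-out lower numbers stand for stronger inhibition and higher numbers for weaker inhibition), compound 1 `O=C1C=CCC/C1=C\c1cnc2ccccc2c1` gives 5250 nM and compound 2 `COc1cc(/C=C2\CCC=CC2=O)cc2ccccc12` gives 3600 nM. These two values are too close to rank.

Compound 3 `COc1cc(/C=C2\CN(C(=O)OCc3ccccc3)C=CC2=O)cc(OC)c1OC` is recorded only as a limit, > 25000 nM, and not as an exact number.

Compound 4 `COc1cc(/C=C2\CN(S(=O)(=O)c3ccc(C)cc3)C=CC2=O)cc(OC)c1OC` keeps the core of compound 3 and changes one group: (4-methylphenyl)sulfonyl in place of benzyloxycarbonyl on an amine nitrogen in a ring. In short, (4-methylphenyl)sulfonyl stands in place of benzyloxycarbonyl on an amine nitrogen in a ring. Going by the values given here, no measured pair of compounds shows this swap on its own, so any forecast rests on thin evidence. A small move toward stronger inhibition is the expected direction, though compound 4 could just as well end up at the same limit. The expected step, an at least 1.6-fold lower number from compound 3 to compound 4 (0.22 log units; that floor lies within the scatter), is an estimate with wide uncertainty. For compound 4 the estimated value is 15000 nM, with an expected range from 5000 nM to 25000 nM.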

Compound 4, half-maximal inhibitory concentration: 19200 nM
Compound 4: middle estimate off by 1.3-fold (0.11 log units), on the low side; the range from low to high includes it.
By their numbers in this assay, from the lowest: compounds 2 and 1 (each within the scatter of the next); then compound 4. At a limit, above all of these: compound 3.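

In this assay, replacing benzyloxycarbonyl with (4-methylphenyl)sulfonyl on an amine nitrogen in a ring gives an at least 1.3-fold lower number from compound 3 to compound 4 (0.11 log units; that floor lies within the scatter). Compound 3 is recorded only as a limit, so this step has a floor but no known upper end: the limit of > 25000 nM in this assay, at which 1 of the 4 values shown sits.

Going by these compounds alone, compound 4, at 19200 nM, provides the first exact number for this shared core, giving later changes at this nitrogen a firm point of comparison that compound 3 cannot offer.

As far as these compounds go, both groups seen on this nitrogen contain a six-membered aromatic ring of carbon only, so it remains open what a much smaller group, such as methyl or acetyl, or a bare hydrogen would give in this assay. Compound 1 and compound 2 differ from compound 4 in more than one place, so they cannot show how this nitrogen and its group contribute.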